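The source may report more compounds than this note shows. Statements on the series, on what has been measured and on what is new or still open speak of the compounds shown alone.

Working notes on the series, read in a functional assay on KB cells (Homo sapiens) for inhibition, read by sulforhodamine B assay, with a stated time of 72 h; on this read-out lower numbers stand for stronger inhibition and higher numbers for weaker inhibition. Compound 3 `COc1ccc(CN(Cc2ccc3ccccc3c2)Cc2c(O)ccc3c(=O)cc(C)oc23)cc1` gives 17.6 ug/mL, the lowest number of the three measured, and its steps to both others lie beyond the scatter. Compound 1 `COc1ccc(CN(Cc2ccccc2)Cc2c(O)ccc3c(=O)cc(C)oc23)cc1` gives 42.7 ug/mL, and compound 2 `CCN(Cc1ccc(OC)cc1)Cc1c(O)ccc2c(=O)cc(C)oc12` gives 47.4 ug/mL. Next is compound 4 `COc1ccc(CN(Cc2ccc(OC)cc2)Cc2c(O)ccc3c(=O)cc(C)oc23)cc1`, with the change 4-methoxyphenyl in place of naphthalen-2-yl on a saturated chain carbon bound to an amine nitrogen. The nearest evidence is the pair of modest steps for naphthalen-2-yl entering at this place, a 2.4-fold lower number from compound 1 to compound 3 (0.38 log units; beyond the scatter) and a 2.7-fold lower number from compound 2 to compound 3 (0.43 log units; beyond the scatter). The step of a 1.1-fold higher number from compound 1 to compound 2 (0.05 log units; within the scatter) lies within the scatter, so phenyl and methyl do not separate here. Within the data shown here, no measured step tests 4-methoxyphenyl against phenyl at this place. Removing naphthalen-2-yl is therefore expected to reverse a modest step of similar size, toward a higher number, and the expected step is a 2.2-fold higher number from compound 3 to compound 4 (0.33 log units; beyond the scatter). Compound 4 is estimated at 38 ug/mL, with an expected range of 20 ug/mL to 70 ug/mL.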

Compound 4, half-maximal inhibitory concentration: 17.8 ug/mL
For compound 4 the middle estimate is 2.1-fold (0.33 log units) above the measured one; the whole stated range lies above it.
By their numbers in this assay, from the lowest: compounds 3 and 4 (each within the scatter of the next); then compounds 1 and 2 (each within the scatter of the next).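

In this assay, the second aromatic ring of naphthalen-2-yl proves unnecessary for the lower number at this place, with a 1.0-fold higher number from compound 3 to compound 4 (0.00 log units; within the scatter) on going to 4-methoxyphenyl, so these two groups do not separate. The gain instead appears with methoxy in place of hydrogen on an aromatic carbon, which gives a 2.4-fold lower number from compound 1 to compound 4 (0.38 log units; beyond the scatter) as a modest step, and the comparison with methyl gives a 2.7-fold lower number from compound 2 to compound 4 (0.43 log units; beyond the scatter) as a step of similar size, so ring count alone does not order the series, since compound 1 and compound 4 each carry a single ring on this carbon yet separate. Nothing measured on these compounds accounts for these steps.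

Going by these compounds, whether methoxy is special on this aromatic carbon remains open, as a hydroxyl, a chlorine or a dimethylamino group there would test it. A longer chain or a pyridine ring in the same place would show how far the level of compound 3 and compound 4 extends.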